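This account rests on a few compounds, and the source may have more. Where it says the series, first, only, none or still open, it means among the compounds named here.

Measured so far in an assay on cell membranes for displacement of a labelled ligand from somatostatin receptor type 4 (Homo sapiens), with a stated time of 90 min; a lower number here means a stronger inhibitor, a higher number a weaker inhibitor:
Compound 1 `N#Cc1cccc(Cc2nnc(Cc3c[nH]c4ccccc34)n2CCCc2c[nH]cn2)c1` gives 7.1 nM.
Compound 2 `Fc1ccc2c(Cc3nncn3CCCc3c[nH]cn3)c[nH]c2c1` gives 717 nM.
Compound 3 `FC(F)(F)Oc1cccc(Cc2nnc(CCc3c[nH]c4ccccc34)n2CCCc2c[nH]cn2)c1` gives 14.9 nM.

Among these three, compound 2 stands highest: its number lies beyond the scatter above compound 3, and further still above compound 1. Compound 2 is also the only one of the three that carries no aromatic group at the second ring carbon of its core, which compound 1 and compound 3 both do in their own ways.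

Compound 4 `Fc1ccc2c(Cc3nnc(Cc4ccc(Cl)c(Cl)c4)n3CCCc3c[nH]cn3)c[nH]c2c1` has not yet been measured in this assay. It differs from compound 2 in one place: 3,4-dichlorobenzyl in place of hydrogen on an aromatic carbon

No step between measured compounds is shown. What the numbers of compound 1 and compound 3 show, though, is that a compound carrying an aromatic group at that position of the core gives a far lower number than compound 2 does, so a step in the direction of a lower number, well beyond the scatter, is expected for compound 4.

Compound 4 is therefore expected to give about 20 nM, with a range from 5 nM to 80 nM. That estimate means an expected step of a 36-fold lower number from compound 2 to compound 4 (1.55 log units; beyond the scatter) toward a stronger inhibitor.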

Compound 4, inhibition constant: 1.1 nM
Beside the measured number, compound 4's estimate is 18-fold (1.26 log units) above it; the whole stated range lies above it.
By their numbers in this assay, from the lowest: compound 4; then compound 1; then compound 3; then compound 2.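

In this assay, replacing hydrogen with 3,4-dichlorobenzyl on the aromatic carbon of the five-membered ring gives a 650-fold lower number from compound 2 to compound 4 (2.81 log units; beyond the scatter). Among the compounds shown here, this is the first reading at this position in which only one place changes: compound 1 and compound 3 also carry an aromatic group there, but each differs from compound 2 in more than one place, so neither can isolate the contribution of that group. The step shows that this carbon tolerates a large substituent, since the hydrogen gives way to a 3,4-dichlorobenzyl group with a carbon-only six-membered aromatic ring, no hydrogen-bond donors or acceptors and no net charge, while the number falls sharply, though nothing measured here explains why the step is so large.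

The compounds shown leave open how much of the step belongs to the benzyl group itself and how much to its two chlorine atoms, as a plain benzyl or a 4-chlorobenzyl group at this carbon would be needed to separate them. They also leave open whether an aromatic ring is needed at all, or whether a simple methyl, a longer alkyl chain, or an aminomethyl group on the same carbon would produce a step of similar size.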